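Swapping the ketone-side ring: methoxyphenyl to methylphenyl

The source may hold more compounds than are shown below. What is called first, only, known or untested is meant among the compounds shown, and "the series" means these compounds.

Compound 1 `C#CCOc1ccc(/C=C/C(=O)c2cccc(OC)c2)cc1OC` is a chalcone-type molecule tested in a functional assay on HCT-116 cells (Homo sapiens) for cytotoxicity, with a stated time of 72 h (a lower number here means a stronger inhibitor, a higher number a weaker inhibitor), where compound 1 gives 1920 nM. Its closest relative among the measured compounds is compound 3 `C#CCOc1ccc(/C=C/C(=O)c2ccc(OC)c(OC)c2)cc1OC`, which in this assay gives 2010 nM; the change a 1.0-fold higher number from compound 1 to compound 3 (0.02 log units; within the scatter) does not move the number beyond the scatter, so the two compounds cannot be ranked against each other. Compound 2 `C=CCc1cc(C(C)=O)ccc1OCC=C(C)C`, built on a different and smaller scaffold, gives 10600 nM, a number clearly higher than that of compound 1, beyond the scatter. Compound 1 thus sits at the low end of the three numbers, shared with compound 3.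

Compound 4 `C#CCOc1ccc(/C=C/C(=O)c2ccccc2C)cc1OC` differs from compound 1 in one place: 2-methylphenyl in place of 3-methoxyphenyl on a carbonyl carbon. Among the compounds with values here, the only measured single-site step, from compound 1 to compound 3, adds a methoxy on that same ring without a change beyond the scatter, which hints that this ring tolerates small alterations. Within the data shown here, no measured step removes a methoxy from it or adds a methyl, so the evidence is thin. A step of little size, in either direction, is expected. Compound 4 is therefore estimated at about 2500 nM, with a range from 1000 nM to 7000 nM. That estimate amounts to an expected step of a 1.3-fold higher number from compound 1 to compound 4 (0.11 log units; within the scatter).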

Compound 4, half-maximal inhibitory concentration: 1660 nM
The estimate for compound 4 lay 1.5-fold (0.18 log units) above the measured number; low and high end bracket the measured number.
By their numbers in this assay, from the lowest: compounds 4, 1 and 3 (each within the scatter of the next); then compound 2.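

In this assay, a 1.2-fold lower number from compound 1 to compound 4 (0.06 log units; within the scatter) shows that this position tolerates more than the small addition seen earlier: here the whole 3-methoxyphenyl group gives way to 2-methylphenyl on a carbonyl carbon. The group that enters has no oxygen and 0 hydrogen-bond acceptors, against 1 for the group that leaves, so a methoxy on this ring is not required for a number of this size, and together with a 1.0-fold higher number from compound 1 to compound 3 (0.02 log units; within the scatter) the ring has now carried none, one and two methoxy groups without a step beyond the scatter. No available measurement explains why the number holds across these changes.

Every compound in this series so far keeps a carbon-only aromatic ring on the carbonyl carbon, so the compounds shown leave open what an amine or a carboxylic acid on that ring would give, or a longer chain such as butyl in place of the methyl. They also do not show whether changes elsewhere on the shared core would move the number beyond the scatter.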